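Opening a ring amine into a chain

This account rests on a few compounds, and the source may have more. Where it says the series, first, only, none or still open, it means among the compounds named here.

For the measured compounds named here, in an ADME assay on the whole organism for metabolic stability, with Mus musculus as the target, at a dose of 3 mg/kg by the intravenous route (on this read-out lower numbers stand for a shorter-lived compound and higher numbers for a longer-lived compound), compound 1 (`CCC[C@H](C)Nc1ncc2c(-c3ccc(CN4CCCN(C)CC4)cc3)cn([C@H]3CC[C@H](O)CC3)c2n1`) gives 3 h and holds the higher of only two numbers so far. Compound 2 (`CCC[C@H](C)Nc1ncc2c(-c3ccc(S(=O)(=O)N4CCN(C)CC4)cc3F)cn([C@H]3CC[C@H](O)CC3)c2n1`) gives 0.65 h in the same test, a gap beyond the usual scatter of repeated measurements.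

Compound 3 (`CCC[C@H](C)Nc1ncc2c(-c3ccc(CNCCN(CC)CC)cc3)cn([C@H]3CC[C@H](O)CC3)c2n1`) has not been measured yet. It keeps the rest of compound 1 and carries one change ((2-(diethylamino)ethyl)amino in place of 4-methyl-1,4-diazepan-1-yl on a saturated chain carbon bound to an aromatic carbon): (2-(diethylamino)ethyl)amino in place of 4-methyl-1,4-diazepan-1-yl on a saturated chain carbon bound to an aromatic carbon. The seven-membered ring is thus replaced by a group with no ring, built from the same number of heavy atoms.

Going by the values given here, no two measured compounds differ in one place only, so no measured step can guide the expectation, and any forecast here is tentative. The estimated 1.4-fold lower number from compound 1 to compound 3 (0.13 log units; within the scatter) is a small one, pointing slightly downward and expected to stay within the scatter. In this assay the estimate for compound 3 is 2.2 h with an expected range from 0.9 h to 5 h for a single measurement.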

Compound 3, half-life: 3.65 h
Compound 3: middle estimate off by 1.7-fold (0.22 log units), on the low side; measured number inside the range.
By their numbers in this assay, from the lowest: compound 2; then compounds 1 and 3 (each within the scatter of the next).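

In this assay, for the compounds shown here, the step from the seven-membered ring to the open chain, on a saturated chain carbon bound to an aromatic carbon, is a 1.2-fold higher number from compound 1 to compound 3 (0.09 log units; within the scatter) and gives the first direct reading of a single change at this position. The step lies within the scatter, so 4-methyl-1,4-diazepan-1-yl and (2-(diethylamino)ethyl)amino cannot be told apart on this read-out, even though the chain has no ring and carries a hydrogen-bond donor that the ring lacks. No supporting data explain why the half-life stays within the scatter when the ring is opened.

This single pair cannot show whether other groups at this place would behave alike, such as a morpholine ring or a shorter chain ending in a dimethylamino group. Going by these compounds, compound 2 differs from compound 1 in more than one place, so its lower number cannot be tied to any one of its changes, and the separate contributions of the sulfonyl link and the fluorine remain open.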